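A Chloro Replaces a Nitro: Expected Inhibition of Compound 3

The compounds below may be only part of what the source reports. "The series", "measured", "known", "first", "only" and "open" are said of these compounds alone.

Measured so far:
compound 1, `NC(=O)[C@@H](NCc1ccc(OCc2ccccc2)cc1)c1ccccc1`, 35%
compound 2, `NC(=O)[C@@H](NCc1ccc(OCc2ccc([N+](=O)[O-])cc2)cc1)c1ccccc1`, 16%

In an assay on mitochondria for inhibition of Amine oxidase [flavin-containing] A (Rattus norvegicus), tested at 100 uM (on this read-out higher numbers stand for more inhibition at the one concentration tested (going by the name of the read-out) and lower numbers for less inhibition), compound 1 gives 35%, and compound 2 gives 16%. Compound 2 thus has the lower of the two numbers, with a number 19 percentage points lower from compound 1 to compound 2 (beyond the scatter) separating it from compound 1.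

Compound 3, `NC(=O)[C@@H](NCc1ccc(OCc2ccc(Cl)cc2)cc1)c1ccccc1`, is not yet measured. Relative to compound 2 the change is chloro in place of nitro on an aromatic carbon. For the measured compounds named here, the only measured step, a number 19 percentage points lower from compound 1 to compound 2 (beyond the scatter), concerns the arrival of the nitro group itself; it shows that a substituent at this position can move the read-out in this assay by a modest amount, but no step tells how a chloro compares with a nitro. On that basis compound 3 is expected to land between the two measured values, most likely with a number 11 percentage points higher from compound 2 to compound 3 (beyond the scatter), though a result within the scatter of compound 2 cannot be ruled out. The estimate for compound 3 is 27%, with a range from 10% to 44%.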

Compound 3, a percentage reported as inhibition, at one concentration (the size of the read-out at that concentration, not a potency): 27%
For compound 3 middle estimate and measured number coincide at the digits printed; the measured number falls inside the stated range.
By their numbers in this assay, from the lowest: compound 2; then compounds 3 and 1 (each within the scatter of the next).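

In this assay, chloro in place of nitro gives a number 11 percentage points higher from compound 2 to compound 3 (beyond the scatter) and so shows that the fall seen with the nitro group does not come with every substituent at this place. Chloro in place of hydrogen gives a number 8 percentage points lower from compound 1 to compound 3 (within the scatter) and so cannot be told apart from hydrogen here, which leaves compound 2 as the only one of the three set off from compound 1. Nothing measured here accounts for the difference between the nitro and the chloro compounds.

With only hydrogen, nitro and chloro shown at this place on the shared core, it remains open whether the lower number is peculiar to the nitro group. As far as these compounds go, how an amine, a methoxy group or a carboxylic acid would read out at the same place also remains open.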